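The source may hold more compounds than are shown below. What is called first, only, known or untested is meant among the compounds shown, and "the series" means these compounds.

Measured compounds:
compound 1, `COc1cc2c(cc1OC)C(=O)C(CC1CCN(C(=S)Nc3cccc(C)c3)CC1)C2` — "not determined" (no result reported)
compound 2, `COc1cc2c(cc1OC)C(=O)C(CC1CCN(C(=S)Nc3ccc([N+](=O)[O-])cc3)CC1)C2` — 100 mg/kg

Among the measured compounds shown here, in a functional assay on the whole organism (strain Swiss albino) with Mus musculus as the target, with a stated time of 0.5 h (a higher number here means that more compound is needed for the effect, a lower number that less compound is needed), compound 2 gives 100 mg/kg; it is the only number, compound 1 having no reported result. Compound 3, `COc1cc2c(cc1OC)C(=O)C(CC1CCN(C(=S)Nc3ccccc3Cl)CC1)C2`, differs from compound 2 by 2-chlorophenyl in place of 4-nitrophenyl on an amide-type nitrogen. For the measured compounds named here, no step between two measured compounds exists to size this kind of change, so the expectation rests on compound 2 alone. The step of no change at the digits printed from compound 2 to compound 3 (within the scatter) is expected to stay within the scatter, with no direction favoured. Compound 3 is thus estimated at 100 mg/kg, with a range from 30 mg/kg to 300 mg/kg.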

Compound 3, minimum effective dose: 300 mg/kg
The estimate for compound 3 lay 3.0-fold (0.48 log units) below the measured number, and the stated range covers the measured number.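

In this assay the aryl group on the amide-type nitrogen, whose other neighbour is the thiocarbonyl carbon, proves sensitive to change: 2-chlorophenyl in place of 4-nitrophenyl gives a 3.0-fold higher number from compound 2 to compound 3 (0.48 log units; beyond the scatter). Among the compounds shown here, this is the first sized step, and it runs towards a larger dose requirement. Nothing at hand explains the step.

Open, from the compounds shown here alone, is whether the step follows from the loss of the nitro group, the presence of chlorine, or the place of the substituent on the ring, since these change together. Results for 4-chlorophenyl or unsubstituted phenyl on the same nitrogen would begin to separate these readings.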